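Aryl variation on the carbonyl carbon of the shared core

A few compounds are considered here, and "the series" means these few. Any claim that something is new, unique, unknown or untested is made for them only; others in the source may bear on it.

The series keeps one shared core and varies the aryl group attached to the carbonyl carbon. Compound 1 `N#Cc1ccc(C(=O)NC(=S)N2CCc3c(OCCCCCOc4ccc(Cl)cc4)cccc32)cc1` carries a 4-cyanophenyl group; in an ADME assay on Huh-7 cells (Homo sapiens) for cytotoxicity (on this read-out higher numbers stand for lower toxicity in this test and lower numbers for higher toxicity in this test), compound 1 gives > 50000 nM, which is a limit of the assay rather than a number (the limit of > 50000 nM in this assay, at which 1 of the 3 values shown sits). Compound 2 `O=C(NC(=S)N1CCc2c(OCCCCCOc3ccc(Cl)cc3)cccc21)c1ccc(F)cc1` carries 4-fluorophenyl, and in this assay compound 2 gives 31100 nM. Compound 3 `O=C(NC(=S)N1CCc2c(OCCCCCOc3ccc(Cl)cc3)cccc21)c1cccnc1` carries pyridin-3-yl, and in this assay compound 3 gives 11100 nM, the lowest of the two numbers, the nearest number being that of compound 2. The steps read a 2.8-fold lower number from compound 2 to compound 3 (0.45 log units; beyond the scatter), an at least 4.5-fold lower number from compound 1 to compound 3 (0.65 log units; beyond the scatter) and an at least 1.6-fold lower number from compound 1 to compound 2 (0.20 log units; that floor lies within the scatter).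

Compound 4 `O=C(NC(=S)N1CCc2c(OCCCCCOc3ccc(Cl)cc3)cccc21)c1ccno1` differs from compound 3 by 1,2-oxazol-5-yl in place of pyridin-3-yl on a carbonyl carbon. Both earlier exchanges of the aryl group on the carbonyl carbon gave steps that were modest in size, so a step of similar size is expected here, with the direction uncertain. The estimate for compound 4 in this assay is 15000 nM, with a range from 6000 nM to 40000 nM. This corresponds to an expected 1.4-fold higher number from compound 3 to compound 4 (0.13 log units; within the scatter).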

Compound 4, half-maximal cytotoxic concentration: 37100 nM
Compound 4: the middle estimate sits 2.5-fold (0.39 log units) below what was measured, within the range that was stated.
By their numbers in this assay, from the lowest: compound 3; then compounds 2 and 4 (each within the scatter of the next). At a limit, above all of these: compound 1.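

In this assay, 1,2-oxazol-5-yl in place of pyridin-3-yl on the carbonyl carbon gives a 3.3-fold higher number from compound 3 to compound 4 (0.52 log units; beyond the scatter), so the exchange of one heteroaromatic group for another at this position moves the read-out beyond the scatter. Set against 4-fluorophenyl, the same group gives a 1.2-fold higher number from compound 2 to compound 4 (0.08 log units; within the scatter), so among the compounds shown a heteroaromatic group does not by itself bring the lower number: compound 3 stands apart, and compound 4 does not follow it. Compound 1 stands at a limit, not a number, so an at least 1.3-fold lower number from compound 1 to compound 4 (0.12 log units; that floor lies within the scatter) reads only as a floor: the limit of > 50000 nM in this assay, at which 1 of the 4 values shown sits.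

With a single pyridine and a single oxazole, the compounds shown do not tell what sets pyridin-3-yl apart from 1,2-oxazol-5-yl. As far as these compounds go, how pyridin-4-yl or 4-aminophenyl on the carbonyl carbon would read in this assay stays open.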